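Swapping fluoro for methylcarbamoyl on two related cores

A few compounds are considered here, and "the series" means these few. Any claim that something is new, unique, unknown or untested is made for them only; others in the source may bear on it.

Compound 1 `CCC1C(=O)N(C)c2cnc(-n3ccc4cc(C(=O)NC)ccc43)nc2N1c1ccn(C)n1` gives 35700 nM in a functional assay on NCI-H1975 cells (Homo sapiens) for antiproliferative activity, read by CCK-8 assay, with a stated time of 72 h; on this read-out lower numbers stand for stronger inhibition of growth and higher numbers for weaker inhibition of growth.
Compound 2 `CCC1C(=O)N(C)c2cnc(-n3ccc4cc(F)ccc43)nc2N1c1ccn(C)n1` gives 28600 nM in this assay.
Compound 3 `CC[C@@H]1C(=O)N(C)c2cnc(-n3ccc4cc(F)ccc43)nc2N1C1CCCC1` gives 46500 nM in this assay.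

Compound 1 and compound 2 share one core and differ by a single change: methylcarbamoyl in place of fluoro on an aromatic carbon. That change made a 1.2-fold higher number from compound 2 to compound 1 (0.10 log units; within the scatter), a step too small to read as a real difference. Compound 3 carries a second core; how the two cores differ is not broken down here, and its value sits within the usual scatter of both compound 1 and compound 2.

Compound 4 `CC[C@@H]1C(=O)N(C)c2cnc(-n3ccc4cc(C(=O)NC)ccc43)nc2N1C1CCCC1` has not been measured. It differs from compound 3 by methylcarbamoyl in place of fluoro on an aromatic carbon, at the same place as the change from compound 2 to compound 1. Because a 1.2-fold higher number from compound 2 to compound 1 (0.10 log units; within the scatter) was small, a similarly small step, a 1.2-fold higher number from compound 3 to compound 4 (0.10 log units; within the scatter), is expected here. Compound 4 is therefore estimated at 58000 nM, expected to lie between 25000 nM and 130000 nM.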

Compound 4, concentration for 50% growth inhibition: 1370 nM
Compound 4: the middle estimate sits 42-fold (1.63 log units) above what was measured; the whole stated range lies above it.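

In this assay, methylcarbamoyl in place of fluoro gave a 34-fold lower number from compound 3 to compound 4 (1.53 log units; beyond the scatter), so a change that did almost nothing on one core made a large difference on the other: the same change on two cores in this assay, a 1.2-fold higher number (0.10 log units; within the scatter) from compound 2 to compound 1 and a 34-fold lower number (1.53 log units; beyond the scatter) from compound 3 to compound 4, 42-fold (1.63 log units) apart, beyond the scatter of two such steps The size of this step on one core therefore cannot be taken as a guide to its size on the other in this series. These two pairs do not show which part of the cores decides the outcome, nor why the outcome differs.

Still open, going by these compounds, is whether a carboxylic acid, a nitrile or a longer amide such as ethylcarbamoyl, placed where methylcarbamoyl sits on compound 4, would give a step of similar size. On these data alone, it is also open how a third core would respond to the same change.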